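From an amine-bearing chain to a fluorinated benzyl group

The compounds below may be only part of what the source reports. "The series", "measured", "known", "first", "only" and "open" are said of these compounds alone.

Of the compounds shown here, three sharing one core have so far been tested in a functional assay on HCT-116 cells (Homo sapiens) for cytotoxicity, read by MTT assay, with a stated time of 72 h; on this read-out lower numbers stand for stronger inhibition and higher numbers for weaker inhibition. Compound 1, `CS(=O)(=O)NCCCN(c1nc(C(=O)NCc2ccc(F)cc2)c(O)c2ncccc12)S(C)(=O)=O`, gives 7000 nM in this assay. Compound 2, `NCCCNc1c(C(=O)NCc2ccc(F)cc2)ncc2cccnc12`, reaches only the limit of this assay, > 10000 nM. From the compounds shown here alone, compound 3, `CNCCCNc1c(C(=O)NCc2ccc(F)cc2)nc(Br)c2cccnc12`, likewise returns only a limit in this assay, > 10000 nM, so its true position among the numbers is unknown beyond that. The next compound, compound 4, `O=C(NCc1ccc(F)cc1)c1nc(Br)c2cccnc2c1NCc1ccc(F)cc1`, has not yet been measured. It differs from compound 3 in one place: 4-fluorophenyl in place of 2-(methylamino)ethyl on a saturated chain carbon bound to a nitrogen on an aromatic ring. Cut one bond further out, the same change reads as 3-(methylamino)propyl to 4-fluorobenzyl on the nitrogen attached to the core. Among the measured compounds shown here, no measured pair here shows what such a change does, so the step from compound 3 to compound 4 is expected to be small, near the scatter, giving an at least 1.1-fold lower number from compound 3 to compound 4 (0.04 log units; that floor lies within the scatter). Because of the limit of > 10000 nM in this assay, at which 2 of the 3 values shown sit, compound 4 is also expected to have a fair chance of returning only a limit. The estimate for compound 4 in this assay is 9000 nM, within a range from 2500 nM to 30000 nM.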

Compound 4, half-maximal inhibitory concentration: > 20000 nM
Compound 4 ended at the assay's limit (the forecaster's own chance of this, stated with the estimate: 55%); middle value at least 2.2-fold (0.34 log units) from the limit.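

Compound 3 and compound 4 each return only a limit, not a number, and the step between them cannot be read. The compounds shown leave open what the change from 3-(methylamino)propyl to 4-fluorobenzyl on the nitrogen attached to the core does in this assay.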